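Geranyl Caffeate Series: Chain Extension Toward Compound 3

The source may report more compounds than this note shows. Statements on the series, on what has been measured and on what is new or still open speak of the compounds shown alone.

Measured so far:
- compound 1 `CC(C)=CCC/C(C)=C/COc1ccc(/C=C/C(=O)O)cc1O`: 12.7%
- compound 2 `CCOC(=O)/C=C/c1ccc(OC/C=C(\C)CCC=C(C)C)c(O)c1`: -7.4%

Going by the values given here, in an assay on isolated protein for inhibition of geranylgeranyl pyrophosphate synthase (Homo sapiens), tested at 100 uM (on this read-out lower numbers stand for less inhibition and higher numbers for more inhibition at the one concentration tested (going by the name of the read-out)), compound 1 stands highest of the two numbers; the only neighbour is compound 2, with a number 20.1 percentage points lower from compound 1 to compound 2 (beyond the scatter). Compound 3 `CC(C)=CCC/C(C)=C/CC/C(C)=C/COc1ccc(/C=C/C(=O)O)cc1O` differs from compound 1 by 3-methylbut-2-en-1-yl in place of hydrogen on a saturated chain carbon bound to a double-bonded chain carbon. Among the compounds with values here, the single measured step concerns the oxygen next to the carbonyl group and does not bear on a change at the saturated chain carbon, so no prior step informs this one. Absent such guidance, the expected step is a number 2.3 percentage points higher from compound 1 to compound 3 (within the scatter), within the scatter. Compound 3 is therefore estimated at 15% with a range of -5% to 35%.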

Compound 3, a percentage reported as inhibition, at one concentration (the size of the read-out at that concentration, not a potency): 16.2%
For compound 3 the middle estimate is 1.2 percentage points below the measured one; measured number inside the range.
By their numbers in this assay, from the lowest: compound 2; then compounds 1 and 3 (each within the scatter of the next).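

In this assay, 3-methylbut-2-en-1-yl in place of hydrogen on a saturated chain carbon bound to a double-bonded chain carbon gives a number 3.5 percentage points higher from compound 1 to compound 3 (within the scatter). This position therefore accepts the longer chain without a change that can be told from scatter, and the free acid of the core stays in place throughout this step. No evidence on the cause accompanies this result.

From the compounds shown here alone, whether a shorter chain or a further 3-methylbut-2-en-1-yl unit here would move the number remains open. Also open, going by these compounds, is whether an amine or an amide in place of the carboxylic acid would change it on the longer chain.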